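This account rests on a few compounds, and the source may have more. Where it says the series, first, only, none or still open, it means among the compounds named here.

Compound 1, `NC(=O)C[C@H](NC(=O)CN(c1ncnc2c1ncn2C1CCCCO1)C1CC1)C(=O)OCc1ccccc1`, gives 29.2% in a functional assay on the whole organism (Tail, strain ICR) with Mus musculus as the target, in the tail flick test, with a stated time of 120 min, at a dose of 25 umol/kg by the oral route; on this read-out higher numbers stand for a stronger effect at the one dose given and lower numbers for a weaker effect.
Compound 2, `CC(C)C[C@H](NC(=O)CN(c1nc(Cl)nc2[nH]cnc12)C1CC1)C(=O)OCc1ccccc1`, gives 8.58% in this assay.
Compound 3, `CC(C)C[C@H](NC(=O)CN(c1ncnc2c1ncn2C1CCCCO1)C1CC1)C(=O)OCc1ccccc1`, gives 12.8% in this assay.

Compound 1 and compound 3 share one core, while compound 2 carries a different one; how the core of compound 2 differs from that of compound 3 is not broken down here. The two values of compound 2 and compound 3 lie within the scatter of each other, whereas compound 1 stands above compound 2 by a gap that is beyond the scatter.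

Within the shared core, the change carbamoyl in place of isopropyl on a saturated chain carbon, two bonds along the chain from an amide-type nitrogen and a carbonyl carbon gives the step of a number 16.4 percentage points higher from compound 3 to compound 1 (beyond the scatter).

Compound 4, `NC(=O)C[C@H](NC(=O)CN(c1nc(Cl)nc2[nH]cnc12)C1CC1)C(=O)OCc1ccccc1`, has not yet been measured. It differs from compound 2 by carbamoyl in place of isopropyl on a saturated chain carbon, two bonds along the chain from an amide-type nitrogen and a carbonyl carbon, the same change on the other core. Because compound 2 gives 8.58% and the step seen was a number 16.4 percentage points higher from compound 3 to compound 1 (beyond the scatter), a step of about a number 16.4 percentage points higher from compound 2 to compound 4 (beyond the scatter) is expected from compound 2 to compound 4. Compound 4 is therefore estimated at 25%, most likely between 12% and 38%.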

Compound 4, a percentage reported as activity, at one dose (the size of the read-out at that dose, not a potency): 15.1%
Estimate against measurement, compound 4: 9.9 percentage points above; the measured number falls inside the stated range.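

Carbamoyl in place of isopropyl on the second core gives a number 6.5 percentage points higher from compound 2 to compound 4 (within the scatter) in this assay, so on this core the change has no effect that can be told from the scatter. Set beside the step on the first core, this one does not differ from it by more than the scatter allows: the same change on two cores in this assay, a number 16.4 percentage points higher (beyond the scatter) from compound 3 to compound 1 and a number 6.5 percentage points higher (within the scatter) from compound 2 to compound 4, 9.9 percentage points apart, within the scatter of two such steps. Going by these compounds alone, the two steps can therefore be read as one and the same step, but they do not prove it: only the step on the first core stands clear of the scatter, so the data show neither that the gain carries over to the second core nor that it depends on the core.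

The compounds shown have only isopropyl or carbamoyl at this place, which leaves open what a carboxylic acid, an amine or a longer chain would give there. Also open, going by these compounds, is whether the step would hold on any core other than these two.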